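The source may report more compounds than this note shows. Statements on the series, on what has been measured and on what is new or still open speak of the compounds shown alone.

Three measured compounds share one core and differ only in the aryl group carried on the amide-type nitrogen in the ring: compound 1 `Cc1cc(/C=C2\SC(=S)N(c3cccc(C(F)(F)F)c3)C2=O)c(C)n1-c1cccc(-c2nnn[nH]2)c1`, compound 2 `Cc1cc(/C=C2\SC(=S)N(c3cccc(Br)c3)C2=O)c(C)n1-c1cccc(-c2nnn[nH]2)c1` and compound 3 `COc1ccc(N2C(=O)/C(=C/c3cc(C)n(-c4cccc(-c5nnn[nH]5)c4)c3C)SC2=S)cc1`. In an ADME assay on MT2 cells (Homo sapiens) for cytotoxicity, read by XTT assay, with a stated time of 4 days (on this read-out lower numbers stand for higher toxicity in this test and higher numbers for lower toxicity in this test), compound 1 gives 15800 nM, compound 2 gives 22600 nM and compound 3 gives 87000 nM. Compound 3 stands highest of the three, beyond the scatter from both others: a 5.5-fold higher number from compound 1 to compound 3 (0.74 log units; beyond the scatter) and a 3.8-fold higher number from compound 2 to compound 3 (0.59 log units; beyond the scatter), whereas a 1.4-fold higher number from compound 1 to compound 2 (0.16 log units; within the scatter).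

Compound 4 `Cc1cc(/C=C2\SC(=S)N(c3ccc(O)cc3)C2=O)c(C)n1-c1cccc(-c2nnn[nH]2)c1` is not yet measured. It differs from compound 3 by hydrogen in place of methyl on an oxygen on an aromatic ring. For the measured compounds named here, no measured step matches this change; the two steps that reach compound 3 each exchange the whole aryl group on that nitrogen and were modest in size, so they give only an indirect sense of how much this position moves the numbers. Compound 4 is therefore expected to show no step beyond the scatter in this assay, a 1.1-fold lower number from compound 3 to compound 4 (0.04 log units; within the scatter). Compound 4 is estimated at 80000 nM in this assay, within 35000 nM to 180000 nM.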

Compound 4, half-maximal cytotoxic concentration: 45600 nM
For compound 4 the middle estimate is 1.8-fold (0.24 log units) above the measured one; the measured number falls inside the stated range.
By their numbers in this assay, from the lowest: compounds 1, 2, 4 and 3 (each within the scatter of the next, the first and the last beyond it).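

Replacing the methyl on the oxygen with hydrogen, methoxy to hydroxy, is the only step shown that keeps the aryl group on the amide-type nitrogen and changes one small substituent, and in this assay it stays within the scatter (a 1.9-fold lower number from compound 3 to compound 4 (0.28 log units; within the scatter)). The 4-hydroxyphenyl group remains beyond the scatter from 3-(trifluoromethyl)phenyl (a 2.9-fold higher number from compound 1 to compound 4 (0.46 log units; beyond the scatter)) but not from 3-bromophenyl (a 2.0-fold higher number from compound 2 to compound 4 (0.30 log units; within the scatter)), whereas the 4-methoxyphenyl group was beyond the scatter from both. Nothing available explains these numbers.

As far as these compounds go, how an amine or a carboxylic acid in place of the hydroxy group, or an ethoxy group in place of methoxy, would read stays open. For the compounds shown here, also open is whether the same change on an oxygen would give a similar step on another aryl group; compound 3 and compound 4 are the only pair carrying it.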